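Carbonyl substituent on the piperidine amide: cyclopentyl to heteroaryl

A few compounds are considered here, and "the series" means these few. Any claim that something is new, unique, unknown or untested is made for them only; others in the source may bear on it.

Measured so far in a functional assay on isolated protein for inhibition of Glucose-dependent insulinotropic receptor (Rattus norvegicus), read by HTRF and cAMP accumulation; on this read-out lower numbers stand for an effect already at smaller amounts and higher numbers for an effect only at larger amounts of compound:
compound 1 `Cc1nc(S(C)(=O)=O)ccc1Oc1ncnc(OC2CCN(C(=O)O[C@@H](C)CF)CC2)c1F` gives 1680 nM
compound 2 `Cc1nc(S(C)(=O)=O)ccc1Oc1ncnc(OC2CCN(C(=O)C3CCCC3)CC2)c1F` gives 407 nM

Among the measured compounds shown here, compound 2 holds the lower of the two numbers in this assay; its only neighbour is compound 1, and the step of a 4.1-fold lower number from compound 1 to compound 2 (0.62 log units; beyond the scatter) is the single measured change at the carbonyl carbon, an exchange of one group of five heavy atoms for another. Compound 3 `Cc1nc(S(C)(=O)=O)ccc1Oc1ncnc(OC2CCN(C(=O)c3nc(C(C)(C)F)no3)CC2)c1F` is the next variation at the same place: a group of 9 heavy atoms (5 carbon, 2 nitrogen, 1 oxygen, 1 fluorine; one five-membered aromatic ring with 3 hetero atoms) in place of a group of 5 heavy atoms (5 carbon; one five-membered non-aromatic ring of carbon only), on a carbonyl carbon. For the measured compounds named here, the entering group is larger and brings three hydrogen-bond acceptors where the cyclopentyl had none, and no measured pair shows an aromatic or heteroatom-bearing group at this carbonyl. Going by the values given here, the only bearing step, from compound 1 to compound 2, shows that this position tolerates a change of group with a modest shift, so a move of similar size either way is plausible, and a number close to that of compound 2 is as likely as a clear gain. Compound 3 is therefore expected to give about 350 nM in this assay, within 100 nM to 1200 nM, a step of a 1.2-fold lower number from compound 2 to compound 3 (0.07 log units; within the scatter) that is expected to stay near the scatter.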

Compound 3, half-maximal effective concentration: 606 nM
The estimate for compound 3 lay 1.7-fold (0.24 log units) below the measured number; the range from low to high includes it.
By their numbers in this assay, from the lowest: compounds 2 and 3 (each within the scatter of the next); then compound 1.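

In this assay the carbonyl carbon accepts an aromatic five-membered ring with 3 hetero atoms in place of cyclopentyl with a 1.5-fold higher number from compound 2 to compound 3 (0.17 log units; within the scatter) and that step stays within the scatter, so a group of 9 heavy atoms with 3 hydrogen-bond acceptors cannot be told apart here from a carbocycle of 5 heavy atoms with none. Measured against the ring-free group of compound 1, the same entering group gives a 2.8-fold lower number from compound 1 to compound 3 (0.44 log units; beyond the scatter) and this lies beyond the scatter, so among these three compounds both ring-bearing groups stand apart from the ring-free one, with no exception. Nothing available bears on why the two ring-bearing groups read alike in this assay.

The compounds shown leave open whether a ring is needed at all on the carbonyl carbon, since a tert-butyl group or a simple isopropyl group would separate the presence of a ring from the absence of the oxygen and fluorine of compound 1. They also leave open how far this tolerance extends, for instance to a phenyl ring, a dimethylamino group or a longer alkyl chain in the same place.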